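Thioether variation on a shared core: estimating compound 4

The source may report more compounds than this note shows. Statements on the series, on what has been measured and on what is new or still open speak of the compounds shown alone.

Measured so far:
Compound 1 `Cc1ccc(CSc2n[nH]c(-n3[se]c4ccccc4c3=O)n2)cc1`: in a functional assay on A549 cells (Homo sapiens) for antiproliferative activity, read by CCK-8 assay, with a stated time of 48 h (on this read-out lower numbers stand for stronger inhibition and higher numbers for weaker inhibition), compound 1 gives > 50000 nM, which is a limit of the assay (the limit of > 50000 nM in this assay, at which 1 of the 3 values shown sits).
Compound 2 `CC(C)Sc1n[nH]c(-n2[se]c3ccccc3c2=O)n1`: in this assay compound 2 gives 36600 nM.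
Compound 3 `Cc1ccccc1CSc1n[nH]c(-n2[se]c3ccccc3c2=O)n1`: in this assay compound 3 gives 9720 nM.

Compound 2 holds the highest of the two numbers; its nearest neighbour is compound 3, with a 3.8-fold lower number from compound 2 to compound 3 (0.58 log units; beyond the scatter). Compound 4 `Cc1cccc(CSc2n[nH]c(-n3[se]c4ccccc4c3=O)n2)c1` differs from compound 2 by 3-methylbenzyl in place of isopropyl on a sulfur. The most direct comparison is a 3.8-fold lower number from compound 2 to compound 3 (0.58 log units; beyond the scatter), where a benzyl group also replaces isopropyl. The opposite pull comes from an at least 5.1-fold lower number from compound 1 to compound 3 (0.71 log units; beyond the scatter) and an at least 1.3-fold lower number from compound 1 to compound 2 (0.13 log units; that floor lies within the scatter), where 4-methylbenzyl sits at the limit. A 3-methylbenzyl group is expected to fall between these, so compound 4 is estimated at 28000 nM, range 9000 nM to 80000 nM, meaning an expected 1.3-fold lower number from compound 2 to compound 4 (0.12 log units; within the scatter), within the scatter.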

Compound 4, half-maximal inhibitory concentration: 12400 nM
Beside the measured number, compound 4's estimate is 2.3-fold (0.35 log units) above it; the measured number falls inside the stated range.
By their numbers in this assay, from the lowest: compounds 3 and 4 (each within the scatter of the next); then compound 2. At a limit, above all of these: compound 1.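

In this assay, 3-methylbenzyl on the sulfur also gives a lower number than isopropyl (a 3.0-fold lower number from compound 2 to compound 4 (0.47 log units; beyond the scatter)), so this gain is not confined to the 2-methylbenzyl of compound 3. The 3-methylphenyl and 2-methylphenyl groups cannot be told apart (a 1.3-fold higher number from compound 3 to compound 4 (0.11 log units; within the scatter)), while 3-methylphenyl separates from 4-methylphenyl (an at least 4.0-fold lower number from compound 1 to compound 4 (0.60 log units; beyond the scatter)). Compound 1 sits at a limit of the assay: the limit of > 50000 nM in this assay, at which 1 of the 4 values shown sits.

Still open, on these data alone, is how an unsubstituted benzyl group would read. Also open, as far as these compounds go, is whether a methoxy group or a carboxylic acid on the phenyl ring would follow the methyl series.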